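The compounds below may be only part of what the source reports. "The series", "measured", "known", "first", "only" and "open" are said of these compounds alone.

Measured so far in a functional assay on EA.hy 926 cells (Homo sapiens) for cytotoxicity, read by MTT assay, with stated times of 24 h and 12 h, tested at 50 uM; a higher number here means a stronger effect of the compound at the concentration tested, a lower number a weaker effect:
compound 1, `COc1cc(/C=C/C(=O)O)ccc1OC(=O)c1nc(C)c(C)nc1C`: 49.1%
compound 2, `COc1cc(/C=C/C(=O)O)cc(OC)c1OC(=O)c1nc(C)c(C)nc1C`: 96.6%
compound 3, `CCOC(=O)/C=C/c1ccc(OC)c(OC(=O)c2nc(C)c(C)nc2C)c1`: 89%

Of these three, compound 1 gives the lowest reading. Its nearest neighbour on the numbers is compound 3, whose value lies well above the scatter band around compound 1, and compound 2 stands higher still. Within the data shown here, the one single-point step among the measured compounds is the change from compound 1 to compound 2, methoxy in place of hydrogen on an aromatic carbon, which gave a number 47.5 percentage points higher from compound 1 to compound 2 (beyond the scatter).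

Compound 4, `Cc1nc(C)c(C(=O)Oc2ccc(/C=C/C(=O)O)cc2O)nc1C`, has not yet been measured. It differs from compound 1 as follows: hydrogen in place of methyl on an oxygen on an aromatic ring. Viewed one bond further out, a methoxy becomes a hydroxy.

Among the measured compounds shown here, no measured pair shows this change, so the step from compound 1 to compound 2 bears on it only by analogy: it shows that altering the substitution on the aromatic ring of compound 1 can move this assay strongly. Removing a methyl from an oxygen is a different move, and the data give no direction for it. He therefore expects a step of a number 7.1 percentage points lower from compound 1 to compound 4 (within the scatter), with a wide range. His estimate for compound 4 in this assay is 42%, between 20% and 65%.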

Compound 4, a percentage reported as activity, at one concentration (the size of the read-out at that concentration, not a potency): 285%
Estimate against measurement, compound 4: 243 percentage points below; measured number outside the range, above it.
By their numbers in this assay, from the lowest: compound 1; then compounds 3 and 2 (each within the scatter of the next); then compound 4.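

In this assay, the oxygen on the aromatic ring proves to be a highly sensitive position: the change from methoxy to hydroxy, with hydrogen in place of methyl, gave a number 235.9 percentage points higher from compound 1 to compound 4 (beyond the scatter). The earlier compounds had shown only that adding a methoxy to the ring of compound 1 could raise the reading; this step shows that the methoxy already present in compound 1 also matters, since removing one methyl, with the rest of the molecule unchanged, moves the reading strongly in the same direction. Nothing in the data shown accounts for this step.

The compounds shown leave open whether the gain depends on the hydroxy itself or simply on the loss of the methyl, a question that an amine in the place of the hydroxy, or an ethoxy or acetoxy group on the same oxygen, would bear on directly. From the compounds shown here alone, it also remains open whether the same change from methoxy to hydroxy would have a comparable effect in compounds carrying an ethyl ester rather than a carboxylic acid, or a second methoxy on the ring.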